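The source may report more compounds than this note shows. Statements on the series, on what has been measured and on what is new or still open speak of the compounds shown alone.

Measured so far in a functional assay on MT4 cells (Homo sapiens) for cytotoxicity; on this read-out lower numbers stand for higher toxicity in this test and higher numbers for lower toxicity in this test:
compound 1 `CC(C)(C)[Si](C)(C)OC[C@H]1O[C@@H](n2cnc3c(N)ncnc32)[C@H](O[Si](C)(C)C(C)(C)C)[C@@]12OS(=O)(=O)C=C2N` gives 7300 nM.
compound 2 `CCn1cnc2ncn([C@@H]3O[C@H](CO[Si](C)(C)C(C)(C)C)[C@@]4(OS(=O)(=O)C=C4N)[C@H]3O[Si](C)(C)C(C)(C)C)c2c1=O` gives > 150000 nM, which is a limit of this assay and not a number.

Compound 2 therefore stands at the limit of this assay; (the limit of > 150000 nM in this assay, at which 1 of the 2 values shown sits). Among the measured compounds shown here, compound 1 is the only compound of the two with a number in this assay.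

Compound 3 `CC(C)(C)[Si](C)(C)OC[C@H]1O[C@@H](n2cnc3c(N)ncnc32)[C@H](O[Si](C)(C)C(C)(C)C)[C@]12OS(=O)(=O)C=C2N` is not yet measured. It differs from compound 2 by a group of 10 heavy atoms (5 carbon, 5 nitrogen; one five-membered aromatic ring with 2 hetero atoms, one six-membered aromatic ring with 2 hetero atoms) in place of a group of 12 heavy atoms (7 carbon, 4 nitrogen, 1 oxygen; one five-membered aromatic ring with 2 hetero atoms, one six-membered aromatic ring with 2 hetero atoms), on a saturated ring carbon. For the measured compounds named here, the group that enters is the group that compound 1 also carries on the shared core; the group that leaves is the one compound 2 carries.

Going by the values given here, no step between two measured compounds exists, so the size of the step from compound 2 to compound 3 cannot be taken from a measured pair. Among the compounds with values here, the only pointer is compound 1, which carries the entering group and gives 7300 nM, a number rather than a limit. The step is expected to go toward higher toxicity in this assay, beyond the scatter: an at least 10-fold lower number from compound 2 to compound 3 (1.00 log units; beyond the scatter) is the estimated step. Compound 3 is thus expected at 15000 nM, within 4000 nM to 100000 nM, with a real chance that only a limit is reported again.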

Compound 3, half-maximal cytotoxic concentration: 13000 nM
For compound 3 the middle estimate is 1.2-fold (0.06 log units) above the measured one; measured number inside the range.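

In this assay, the group of 10 heavy atoms in place of the group of 12 heavy atoms, on a saturated ring carbon, gives an at least 11-fold lower number from compound 2 to compound 3 (1.06 log units; beyond the scatter) and moves the series from the edge of the read-out to a measurable level. On these data alone, that step starts from a limit and not a number, so its true size stays unknown: the limit of > 150000 nM in this assay, at which 1 of the 3 values shown sits. Compounds 1 and 3 carry the same groups, and a 1.8-fold higher number from compound 1 to compound 3 (0.25 log units; within the scatter) shows that this change of one stereocentre at a saturated ring carbon does not separate them in this read-out: the fact that compounds 1 and 3 differ only in the configuration as drawn.

The two groups on the saturated ring carbon differ in their atoms and in hydrogen-bond donors, and the compounds shown do not tell which of these differences accounts for the step, nor whether the group of 12 heavy atoms would also be insensitive to configuration. Also open, as far as these compounds go, is how this assay would respond to a simple amine or a carboxylic acid in this place, or to a change in the other groups on the shared core, which stay the same throughout.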